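Trimethoxyphenyl pyrazole chalcones: removing one methoxy

The source may report more compounds than this note shows. Statements on the series, on what has been measured and on what is new or still open speak of the compounds shown alone.

Measured so far in a functional assay on NCI-H322M cells (Homo sapiens) for cytotoxicity, read by sulforhodamine B assay, with a stated time of 48 h, tested at 1 uM; a lower number here means a stronger effect, a higher number a weaker effect of the compound at the concentration tested:
compound 1, `COc1ccc(-c2cc(/C=C/C(=O)c3ccc(N)cc3)[nH]n2)cc1`, 69%
compound 2, `COc1cc(-c2cc(/C=C/C(=O)c3ccc(N)cc3)[nH]n2)cc(OC)c1OC`, 94%
compound 3, `COc1ccc(C(=O)/C=C/c2cc(-c3cc(OC)c(OC)c(OC)c3)n[nH]2)cc1OC`, 83%

Compound 2 has the highest number of the three, the weakest effect in this assay. Among the measured compounds shown here, its nearest neighbour is compound 3, which gives 83%, and the single measured step shows a number 11 percentage points lower from compound 2 to compound 3 (beyond the scatter). Furthest off is compound 1, which gives 69%; compound 1 and compound 2 differ in two places, so no single step covers that gap, and the two values alone show the mono-methoxy compound well below the trimethoxy compound.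

Compound 4, `COc1ccc(-c2cc(/C=C/C(=O)c3ccc(N)cc3)[nH]n2)cc1OC`, differs from compound 2 by hydrogen in place of methoxy on an aromatic carbon. For the measured compounds named here, no measured step removes a methoxy from the aryl group on the pyrazole, so the step from compound 2 to compound 4 has no direct precedent. Going by the values given here, the only related information is the pair compound 1 and compound 2, where fewer methoxy groups go with a lower number. Compound 4 sits between those two structures in methoxy count, so a step downward from compound 2 is expected, though with wide uncertainty.

The estimate for compound 4 in this assay is 81%, in the range 63% to 97%, which corresponds to an expected a number 13 percentage points lower from compound 2 to compound 4 (beyond the scatter).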

Compound 4, a percentage reported as activity, at one concentration (the size of the read-out at that concentration, not a potency): 95%
Compound 4: the middle estimate sits 14 percentage points below what was measured; low and high end bracket the measured number.
By their numbers in this assay, from the lowest: compound 1; then compound 3; then compounds 2 and 4 (each within the scatter of the next).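

Hydrogen in place of methoxy at this aromatic carbon, ortho to a methoxy group, gives a step within the scatter in this assay: a number 1 percentage points higher from compound 2 to compound 4 (within the scatter), so among these compounds the methoxy at this position is not needed to keep the read-out where it stands. The methoxy step on the same ring that does register is a different one, methoxy in place of hydrogen on an aromatic carbon, with a number 26 percentage points higher from compound 1 to compound 4 (beyond the scatter), so the two single-place steps on this ring are not alike in size, and a simple count of methoxy groups does not describe them. Nothing measured here gives a reason for either step.

As far as these compounds go, whether the position tolerates anything other than methoxy and hydrogen remains open, for example a hydroxyl, a chlorine or an amine on the same carbon. Also open, from the compounds shown here alone, is whether the same holds with 3,4-dimethoxyphenyl in place of 4-aminophenyl on the carbonyl carbon, and whether a read-out at one concentration reflects the order of potency.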